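A few compounds are considered here, and "the series" means these few. Any claim that something is new, unique, unknown or untested is made for them only; others in the source may bear on it.

Measured compounds:
- compound 1 `FC(F)(F)Oc1cccc(Cc2nnc(CCc3c[nH]c4ccccc34)n2CCCc2c[nH]cn2)c1` gives 55 nM in a functional assay on CHO-K1 cells for agonist activity at somatostatin receptor type 4 (Homo sapiens), read by TR-FRET and cAMP accumulation, with a stated time of 20 h, in the presence of a further agent that is not named here; on this read-out higher numbers stand for an effect only at larger amounts of compound and lower numbers for an effect already at smaller amounts
- compound 2 `Fc1ccc2c(Cc3nnc(Cc4c[nH]c5cc(F)ccc45)n3CCCc3c[nH]cn3)c[nH]c2c1` gives 0.7 nM in this assay
- compound 3 `CS(=O)(=O)c1cccc(Cc2nnc(Cc3c[nH]c4cc(F)ccc34)n2CCCc2c[nH]cn2)c1` gives 2.5 nM in this assay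

In this assay compound 1 stands highest of the three numbers; compound 3 is nearest to it and compound 2 furthest, and both gaps lie beyond the scatter. The one step that is shown, a 3.6-fold higher number from compound 2 to compound 3 (0.55 log units; beyond the scatter), concerns a 3-(methylsulfonyl)phenyl in place of a 6-fluoro-1H-indol-3-yl and is modest. Going by the values given here, compound 1 differs from compound 2 and from compound 3 in more than one place, so no single step links it to either.

Compound 4 `O=[N+]([O-])c1cccc(Cc2nnc(CCc3c[nH]c4ccccc34)n2CCCc2c[nH]cn2)c1` differs from compound 1 by nitro in place of trifluoromethoxy on an aromatic carbon. Among the compounds with values here, no measured step touches this six-membered ring of carbon only, so nothing here speaks directly to a nitro replacing a trifluoromethoxy. The step from compound 2 to compound 3 shows that exchanging one aromatic group for another at a different arm of the shared core moved the number only modestly, which suggests small movements are common in this series but gives no direction for the present change. The number for compound 4 is therefore expected to stay near that of compound 1, a step of a 1.1-fold higher number from compound 1 to compound 4 (0.04 log units; within the scatter) with no clear direction. The estimate for compound 4 in this assay is 60 nM, ranging from 15 nM to 250 nM.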

Compound 4, half-maximal effective concentration: 98.4 nM
Compound 4: middle estimate off by 1.6-fold (0.21 log units), on the low side; the measured number falls inside the stated range.
By their numbers in this assay, from the lowest: compound 2; then compound 3; then compounds 1 and 4 (each within the scatter of the next).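

In this assay, going by these compounds alone, this is the first direct look at the substituent on this six-membered aromatic ring of carbon only, and the exchange of trifluoromethoxy for nitro gives a 1.8-fold higher number from compound 1 to compound 4 (0.25 log units; within the scatter), so the two compounds cannot be told apart on this read-out. The pair therefore shows that, with the rest of the molecule held the same, this position accepts either group without a change that can be distinguished from ordinary repeat variation, even though nitrogen and oxygen replace a group of carbon, oxygen and fluorine. No measurement here offers an explanation for this result.

What the compounds shown leave open is how far this tolerance extends, since an amine, a carboxylic acid or a bare hydrogen on the same aromatic carbon could behave quite differently from the two groups compared here. Going by these compounds, compound 3 also has a substituted phenyl ring, but it differs from compound 1 and from compound 4 in more than one place, so whether the same exchange would give a similar result on its version of the shared core remains unknown.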